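This account rests on a few compounds, and the source may have more. Where it says the series, first, only, none or still open, it means among the compounds named here.

Of the compounds shown here, three have been measured in an assay on COS-7 cells for inhibition of patatin-like phospholipase domain-containing protein 2 (Mus musculus), tested at 200 uM; a higher number here means more inhibition at the concentration tested (going by the name of the read-out), a lower number less inhibition. Compound 1 `CCOC(=O)c1cccc(-c2ccc(OCC)cc2)n1` gives 79%. Compound 2 `CCOC(=O)c1cccc(-c2ccc(OCC)nc2)c1` gives 68%. Compound 3 `CCOc1ccc(-c2cccc(S(=O)(=O)NC)c2)cc1` gives 47%, the lowest of the three numbers; the nearest to it is compound 2, whose number is higher by a difference beyond the scatter, and the furthest is compound 1, whose number is higher by a still larger difference, also beyond the scatter.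

Compound 4 `CCOc1ccc(-c2cccc(C(=O)N3CCCC3)c2)cc1` has not yet been measured. It differs from compound 3 in one place: (pyrrolidin-1-yl)carbonyl in place of methylsulfamoyl on an aromatic carbon. Within the data shown here, no two measured compounds differ in only one place, so no measured step shows how large a change of this kind can be. Among the measured compounds shown here, the only guide is that both compounds carrying a carbonyl rather than a sulfonamide sit higher: compound 1 gives 79% and compound 2 gives 68%. The step of a number 13 percentage points higher from compound 3 to compound 4 (beyond the scatter) is therefore expected to be upward, of modest size, with wide uncertainty. For compound 4 the expected inhibition in this assay is 60%, within a range from 35% to 85%.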

Compound 4, a percentage reported as inhibition, at one concentration (the size of the read-out at that concentration, not a potency): 53%
The estimate for compound 4 lay 7 percentage points above the measured number, and the stated range covers the measured number.
By their numbers in this assay, from the lowest: compounds 3 and 4 (each within the scatter of the next); then compound 2; then compound 1.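

In this assay, among these compounds, the change at this aromatic carbon gives a number 6 percentage points higher from compound 3 to compound 4 (within the scatter), the first step where only one place differs. This position therefore takes two rather different groups with no readable difference: methylsulfamoyl, with no ring and 1 hydrogen-bond donor, and (pyrrolidin-1-yl)carbonyl, with a five-membered non-aromatic ring and 0 hydrogen-bond donors. The data give no measured property of either group that could explain this result.

Going by these compounds, whether any group at this aromatic carbon separates from these two remains open, for instance a carboxylic acid or a primary amine on the same core. The read-out is also taken at one concentration, so it leaves open whether compound 3 and compound 4 would match in potency across a range of concentrations.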